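A few compounds are considered here, and "the series" means these few. Any claim that something is new, unique, unknown or untested is made for them only; others in the source may bear on it.

Measured so far in a functional assay on the whole organism (strain albino) for inhibition, with Rattus norvegicus as the target, read by paw edema, with stated times of 1 h and 3 h, at a dose of 20 mmol/kg by the intraperitoneal route; on this read-out lower numbers stand for a weaker effect and higher numbers for a stronger effect at the one dose given:
compound 1 `N#CC1=C(NCN2CCCC2)N(c2ccccc2)C(=O)N2CCCCC(N3CCCC3)C12` gives 35.3%;
compound 2 `N#CC1=C(/N=C/Nc2ccc([N+](=O)[O-])cc2)N(c2ccccc2)C(=O)N2CCCCC(N3CCCC3)C12` gives 85.6%.

Among the compounds with values here, compound 1 stands lowest of the two numbers; its only neighbour is compound 2, reached by a number 50.3 percentage points higher from compound 1 to compound 2 (beyond the scatter), a step beyond the scatter.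

Compound 3 `COc1ccc(/C=N/C2=C(C#N)C3C(N4CCCC4)CCCCN3C(=O)N2c2ccccc2)cc1` has not yet been measured. It differs from compound 1 thus: a group of 10 heavy atoms (8 carbon, 1 nitrogen, 1 oxygen; one six-membered aromatic ring of carbon only) in place of a group of 7 heavy atoms (5 carbon, 2 nitrogen; one five-membered non-aromatic ring with 1 hetero atom), on a double-bonded ring carbon. Within the data shown here, the one measured step that bears on this change is the step from compound 1 to compound 2, where a group holding a six-membered aromatic ring likewise replaced the five-membered non-aromatic ring on the same double-bonded ring carbon; the measured change there was a number 50.3 percentage points higher from compound 1 to compound 2 (beyond the scatter). Among the measured compounds shown here, the entering group of compound 3 carries a methoxy group where compound 2 carries a nitro group, and no step separates those two choices. Because a number 50.3 percentage points higher from compound 1 to compound 2 (beyond the scatter) was large for a change of the same kind, a rise is expected for compound 3 in this assay, though not necessarily of the full size seen there. Compound 3 is expected to give a number 34.7 percentage points higher from compound 1 to compound 3 (beyond the scatter), which means about 70%, in a range of 50% to 88%.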

Compound 3, a percentage reported as inhibition, in the whole organism at one dose (the size of the read-out at that dose, not a potency): 75.3%
Compound 3: middle estimate off by 5.3 percentage points, on the low side; the range from low to high includes it.
By their numbers in this assay, from the lowest: compound 1; then compound 3; then compound 2.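

On the double-bonded ring carbon, a second aromatic entering group also lifts the read-out in this assay, with a number 40 percentage points higher from compound 1 to compound 3 (beyond the scatter), so the rise on losing ((pyrrolidin-1-yl)methyl)amino is not tied to the (4-nitrophenyl)amino-bearing group of compound 2. The two aromatic groups do not read the same: 4-methoxyphenyl in place of (4-nitrophenyl)amino on a carbon with a double bond to nitrogen gives a number 10.3 percentage points lower from compound 2 to compound 3 (beyond the scatter), a modest step.

That step changes the ring substituent and the link to the ring together, and the compounds shown do not separate the two; a 4-nitrophenyl or a plain phenyl group on the same carbon would do so. Also open, on these data alone, is whether an aromatic ring is needed at all, which a cyclohexyl group there would test. No measurement offered here explains either step.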